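This account rests on a few compounds, and the source may have more. Where it says the series, first, only, none or still open, it means among the compounds named here.

Measured compounds, with their values in a functional assay on the whole organism for agonist activity, with Mus musculus as the target; on this read-out lower numbers stand for an effect already at smaller amounts and higher numbers for an effect only at larger amounts of compound:
compound 1 `COC(=O)N(C)C(C)C#CCn1ccnc1` gives 8 mg/kg
compound 2 `COC(=O)N(C)C(C)C#CCN(C)C` gives 17.3 mg/kg
compound 3 `CN1CCN(CC#CCn2ccnc2)C1=O` gives 1.4 mg/kg

Compound 3 has the lowest number of the three; its nearest neighbour is compound 1, and compound 2 stands furthest from it. The difference between the core of compound 3 and the core of compound 1 is not broken down here.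

Compounds 1 and 2 differ in one place: dimethylamino in place of 1H-imidazol-1-yl on a saturated chain carbon bound to a triple-bonded carbon. That change made the step of a 2.2-fold higher number from compound 1 to compound 2 (0.33 log units; beyond the scatter).

Compound 4 `CN(C)CC#CCN1CCN(C)C1=O` has not yet been measured in this assay. It differs from compound 3 in the same way: dimethylamino in place of 1H-imidazol-1-yl on a saturated chain carbon bound to a triple-bonded carbon. The place is described in the same words for both pairs, so this is taken as the same kind of change. For the measured compounds named here, the expectation for compound 4 rests on that one earlier step; it is the only instance of the change with a measured outcome, and how far it carries over to the core of compound 3 is unknown. For compound 4 the expected step is a 2.1-fold higher number from compound 3 to compound 4 (0.33 log units; beyond the scatter), of a size close to the earlier one. Compound 4 is therefore estimated at 3 mg/kg, with the range 1.5 mg/kg to 6.5 mg/kg.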

Compound 4, dose for half-maximal effect: 0.54 mg/kg
Beside the measured number, compound 4's estimate is 5.6-fold (0.74 log units) above it, and the stated range ends above it.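

In this assay, dimethylamino in place of 1H-imidazol-1-yl on a saturated chain carbon bound to a triple-bonded carbon gave a 2.6-fold lower number from compound 3 to compound 4 (0.41 log units; beyond the scatter), a step opposite in direction to the one seen on the core of compound 1. The two outcomes of this change do not agree: the same change on two cores in this assay, a 2.2-fold higher number (0.33 log units; beyond the scatter) from compound 1 to compound 2 and a 2.6-fold lower number (0.41 log units; beyond the scatter) from compound 3 to compound 4, 5.6-fold (0.75 log units) apart, beyond the scatter of two such steps. The step on one core therefore did not carry over to the other in this series, but with a single pair on each core, the data do not show which feature of the cores goes with the reversal, or what the change would do on a further core.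

Open, on these data alone, is whether pyrrolidin-1-yl or piperidin-1-yl in the same place would follow dimethylamino or 1H-imidazol-1-yl on either core. Also open, as far as these compounds go, is whether a longer chain would keep the order seen between compound 3 and compound 4.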